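A Sulfur-Linked Amine Chain on a Fluorinated Indole Core

The compounds below may be only part of what the source reports. "The series", "measured", "known", "first", "only" and "open" are said of these compounds alone.

Three compounds share one core and were tested in an assay on isolated protein (urine) for inhibition of Myeloperoxidase (Homo sapiens), with a stated time of 5 min; on this read-out higher numbers stand for weaker inhibition and lower numbers for stronger inhibition. Compound 1 `NC(=O)CCCCc1c[nH]c2ccc(F)cc12` gives 39 nM. Compound 2 `NCCCc1c[nH]c2c(F)cccc12` gives 24 nM. Compound 3 `NCCCc1c[nH]c2ccc(C(=O)O)cc12` was reported as "not active" (no number reported), without a number. Among the two numbers reported, compound 1 and compound 2 lie within the usual scatter of each other, so neither can be called the stronger inhibitor on this evidence, and compound 3 gives no number to compare.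

Compound 4 `NCCSCCc1c[nH]c2ccc(F)cc12` is the next compound to be measured in this assay. It differs from compound 1 in one place: (2-aminoethyl)sulfanyl in place of 2-carbamoylethyl on a saturated chain carbon, two bonds along the chain from an aromatic carbon. The chain that leaves carries a carbonyl and an amide hydrogen, while the chain that enters carries sulfur and a free amino group. Compounds 2 and 3 also carry chains ending in an amino group, and compound 2 gives 24 nM, a number close to that of compound 1. For the measured compounds named here, nothing among the measured compounds tells how much a change of this kind moves the read-out.

The expected step of a 1.6-fold lower number from compound 1 to compound 4 (0.19 log units; within the scatter) is therefore small, no larger than the scatter, with no clear direction. Compound 4 is estimated at 25 nM, with a range from 8 nM to 80 nM.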

Compound 4, half-maximal inhibitory concentration: 4 nM
For compound 4 the middle estimate is 6.3-fold (0.80 log units) above the measured one; measured number outside the range, below it.
By their numbers in this assay, from the lowest: compound 4; then compounds 2 and 1 (each within the scatter of the next).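

In this assay, (2-aminoethyl)sulfanyl in place of 2-carbamoylethyl gives a 9.8-fold lower number from compound 1 to compound 4 (0.99 log units; beyond the scatter), a step beyond the usual scatter. For the compounds shown here, this is the only step available at this place on the chain, and it shows that the read-out responds to what the chain carries there: the chain with sulfur and a free amino group inhibits more strongly than the one with a carbonyl and an amide hydrogen. No measurement shown here gives a reason for this step.

The sulfur and the free amino group enter together, so the compounds shown do not reveal what each contributes, or whether an all-carbon chain ending in an amine or an oxygen in place of the sulfur would do the same. Going by these compounds, it also remains open whether a longer chain would keep this level of inhibition on the shared core.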